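From an amide to a sulfonamide on a shared core

The source may hold more compounds than are shown below. What is called first, only, known or untested is meant among the compounds shown, and "the series" means these compounds.

In a functional assay on A549 cells (Homo sapiens) for antiproliferative activity, read by MTT assay, with a stated time of 72 h (a higher number here means a weaker inhibitor, a lower number a stronger inhibitor), compound 1 `CN(C(=O)c1ccc(F)cc1)c1ccc2[nH]c(-c3n[nH]c4ccccc34)cc2n1` gives 9650 nM. Compound 2 `CN(C(=O)c1ccccc1)c1ccc2[nH]c(-c3n[nH]c4cc(C#N)ccc34)cc2n1` gives 32800 nM. Of these two numbers, compound 1 holds the lower one, and the gap to compound 2 lies beyond the scatter. Compound 3 `CN(c1ccc2[nH]c(-c3n[nH]c4ccccc34)cc2n1)S(=O)(=O)c1ccc(Cl)cc1` carries (4-chlorophenyl)sulfonyl in place of (4-fluorophenyl)carbonyl on a nitrogen on an aromatic ring. Among the compounds with values here, no measured pair isolates a change of this kind, so its direction remains open. The expected step is a 1.2-fold higher number from compound 1 to compound 3 (0.09 log units; within the scatter), modest in size, with no clear direction beyond the scatter. Compound 3 is therefore estimated to give about 12000 nM, within a range from 3000 nM to 50000 nM.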

Compound 3, half-maximal inhibitory concentration: 18200 nM
Estimate against measurement, compound 3: 1.5-fold (0.18 log units) below, and the stated range covers the measured number.
By their numbers in this assay, from the lowest: compounds 1, 3 and 2 (each within the scatter of the next, the first and the last beyond it).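

Placing (4-chlorophenyl)sulfonyl in place of (4-fluorophenyl)carbonyl on this nitrogen gives a 1.9-fold higher number from compound 1 to compound 3 (0.28 log units; within the scatter) in this assay, so the two compounds cannot be told apart here. This nitrogen can therefore carry either a carbonyl or a sulfonyl link, at least with these two aryl groups, and activity stays within the scatter. No measurement on hand offers a reason for this result. From the compounds shown here alone, because the link and the ring halogen change together, the effect of each alone remains unknown. Going by these compounds, how an amine or a longer alkyl chain on this nitrogen would fare also stays open.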